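Azidomethyl in place of pent-1-en-1-yl on the carbonyl carbon

This account rests on a few compounds, and the source may have more. Where it says the series, first, only, none or still open, it means among the compounds named here.

In a functional assay on KYSE-450 cells (Homo sapiens) for inhibition, read by MTT assay, with a stated time of 48 h (on this read-out lower numbers stand for stronger inhibition and higher numbers for weaker inhibition), three measured compounds share one core and differ only in the chain on the carbonyl carbon. Compound 1 (`CCCCC(=O)N(Cc1ccc(OC)c(O)c1)c1cc(OC)c(OC)c(OC)c1`) carries butyl and gives 300 nM here. Compound 2 (`C/C=C/C=C/C(=O)N(Cc1ccc(OC)c(O)c1)c1cc(OC)c(OC)c(OC)c1`) carries penta-1,3-dien-1-yl and gives 180 nM here. Compound 3 (`CCC/C=C/C(=O)N(Cc1ccc(OC)c(O)c1)c1cc(OC)c(OC)c(OC)c1`) carries pent-1-en-1-yl and gives 57 nM as the lowest number of the three, with both other compounds beyond the scatter from it.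

Compound 4 (`COc1ccc(CN(C(=O)CN=[N+]=[N-])c2cc(OC)c(OC)c(OC)c2)cc1O`) has azidomethyl in place of pent-1-en-1-yl on the same carbonyl carbon (azidomethyl in place of pent-1-en-1-yl on a carbonyl carbon) and has not yet been measured. The measured steps at this place are a 1.7-fold lower number from compound 1 to compound 2 (0.22 log units; within the scatter) and a 5.3-fold lower number from compound 1 to compound 3 (0.72 log units; beyond the scatter) and a 3.2-fold lower number from compound 2 to compound 3 (0.50 log units; beyond the scatter) in all. None of them brings in azidomethyl, so they offer only a rough size for chain changes here.

Neither other chain reached the number of compound 3, so leaving pent-1-en-1-yl is expected to raise the number in this assay by a step close to a 5.3-fold lower number from compound 1 to compound 3 (0.72 log units; beyond the scatter) or somewhat larger. The expected step is a 6.1-fold higher number from compound 3 to compound 4 (0.79 log units; beyond the scatter) on this estimate. Compound 4 is estimated at 350 nM with an expected range from 90 nM to 1500 nM in this read-out.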

Compound 4, half-maximal inhibitory concentration: 160 nM
Beside the measured number, compound 4's estimate is 2.2-fold (0.34 log units) above it; measured number inside the range.
By their numbers in this assay, from the lowest: compound 3; then compounds 4, 2 and 1 (each within the scatter of the next).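

The azidomethyl chain, which carries nitrogen in place of an all-carbon chain on the carbonyl carbon, is tolerated in this assay without matching pent-1-en-1-yl, with a 2.8-fold higher number from compound 3 to compound 4 (0.45 log units; beyond the scatter), so compound 3 keeps the lowest number in the series. Against the other two chains there is no separation: the change shows a 1.1-fold lower number from compound 2 to compound 4 (0.05 log units; within the scatter) and a 1.9-fold lower number from compound 1 to compound 4 (0.27 log units; within the scatter), so azidomethyl, penta-1,3-dien-1-yl and butyl form one level in this read-out, and only pent-1-en-1-yl stands apart from it. No measurement at hand bears on why the pent-1-en-1-yl chain stands apart from the other three.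

Open, from the compounds shown here alone, is whether the low number of compound 3 depends on its double bond or on the chain itself, which a saturated pentyl chain on the same carbonyl carbon would help to separate. Equally open, going by these compounds, is how far this position accepts other nitrogen-bearing chains, such as aminomethyl or a longer azidobutyl chain, or a chain ending in a carboxylic acid.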